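The source may report more compounds than this note shows. Statements on the series, on what has been measured and on what is new or still open speak of the compounds shown alone.

Working notes on the series. Compound 1 `CCOC(=O)/C=C/C(=O)N(CC(N)=O)NC(=O)[C@@H]1CCCN1C(=O)C(C)(C)NC(C)=O` gives 198 nM in an assay on isolated protein for inhibition of legumain (Mus musculus), read by fluorescence, with stated times of 30 s and 2.5 h; a higher number here means a weaker inhibitor, a lower number a stronger inhibitor. Among the compounds with values here, compound 2 `C#CC[C@H](NC(C)=O)C(=O)N1CCC[C@H]1C(=O)NN(CC(N)=O)C(=O)/C=C/C(=O)OCC` gives 17 nM, the lowest of the two numbers measured so far; the step of a 12-fold lower number from compound 1 to compound 2 (1.07 log units; beyond the scatter) was the single large move in the set. Compound 3 `CCOC(=O)/C=C/C(=O)N(CC(N)=O)NC(=O)[C@@H]1CCCN1C(=O)c1ccc(CNC(C)=O)cc1` has not been measured yet; it differs from compound 2 by a group of 11 heavy atoms (9 carbon, 1 nitrogen, 1 oxygen; one six-membered aromatic ring of carbon only) in place of a group of 8 heavy atoms (6 carbon, 1 nitrogen, 1 oxygen; no ring), on a carbonyl carbon, with the 4-(acetamidomethyl)phenyl group entering on the carbonyl carbon. Within the data shown here, only the step from compound 1 to compound 2 bears on this, and it shows that changes on this carbonyl carbon can move the number well beyond the scatter. A weaker number than compound 2 is expected, with the step of a 4.7-fold higher number from compound 2 to compound 3 (0.67 log units; beyond the scatter). Compound 3 is estimated at 80 nM, within 20 nM to 320 nM.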

Compound 3, half-maximal inhibitory concentration: 267 nM
Estimate against measurement, compound 3: 3.3-fold (0.52 log units) below, within the range that was stated.
By their numbers in this assay, from the lowest: compound 2; then compounds 1 and 3 (each within the scatter of the next).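

On the carbonyl carbon whose other neighbour is the amide-type nitrogen in a ring, 4-(acetamidomethyl)phenyl gives a 16-fold higher number from compound 2 to compound 3 (1.20 log units; beyond the scatter) in this assay and so does not keep the number of compound 2. Set against 1-acetamido-1-methylethyl, the same group gives a 1.3-fold higher number from compound 1 to compound 3 (0.13 log units; within the scatter) in this assay and thus does not separate from compound 1. No measured evidence accounts for either step. Of these three groups, only that of compound 2 has a triple bond and a defined stereocentre, and the compounds shown cannot separate those two features. Also open, from the compounds shown here alone, is how plain phenyl or a longer chain would read at this carbonyl carbon.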